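Chloro to bromo on the diaryl thiophene amide series

The source may hold more compounds than are shown below. What is called first, only, known or untested is meant among the compounds shown, and "the series" means these compounds.

Measured so far:
compound 1 `COC(=O)c1c(N)sc(-c2ccc(Cl)cc2)c1-c1ccc(Cl)cc1` gives 2780 nM in a functional assay on PC-3 cells (Homo sapiens) for cytotoxicity, read by sulforhodamine B assay, with a stated time of 72 h; a lower number here means a stronger inhibitor, a higher number a weaker inhibitor
compound 2 `Nc1sc(-c2ccc(Cl)cc2)c(-c2ccc(Cl)cc2)c1C(=O)NC1CC1` gives 3680 nM in this assay

Compound 2 carries a cyclopropylamino in place of the methoxy on the carbonyl carbon of compound 1; the step of a 1.3-fold higher number from compound 1 to compound 2 (0.12 log units; within the scatter) is within the scatter, so the two numbers cannot be told apart. Compound 3 `Nc1sc(-c2ccc(Br)cc2)c(-c2ccc(Cl)cc2)c1C(=O)NC1CC1` is the next compound, not yet measured in this assay. It differs from compound 2 by bromo in place of chloro on an aromatic carbon, on an aromatic carbon of a six-membered aromatic ring of carbon only, para to a large group. Going by the values given here, no measured step touches that ring, so there is nothing to bear on it; the one step seen, from compound 1 to compound 2, was within the scatter. The step of a 1.1-fold lower number from compound 2 to compound 3 (0.02 log units; within the scatter) is therefore expected to be none beyond the scatter. Compound 3 is estimated at 3500 nM, within 1700 nM to 7200 nM.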

Compound 3, half-maximal inhibitory concentration: 37300 nM
Compound 3: middle estimate off by 11-fold (1.03 log units), on the low side; the whole stated range lies below it.
By their numbers in this assay, from the lowest: compounds 1 and 2 (each within the scatter of the next); then compound 3.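

The 4-chlorophenyl to 4-bromophenyl change swaps one halogen for another, with no ring, hydrogen-bond donor, acceptor or charge entering or leaving, yet in this assay it gives a large step, a 10-fold higher number from compound 2 to compound 3 (1.01 log units; beyond the scatter), so this place on the ring responds strongly to a small change. Going by these compounds alone, the only earlier step, a 1.3-fold higher number from compound 1 to compound 2 (0.12 log units; within the scatter), lay at the carbonyl carbon and did not touch this ring. Nothing shown here accounts for the size of the new step.

From the compounds shown here alone, whether the weakening is specific to bromo or extends to other groups at this place, such as fluoro, methyl or methoxy, remains open. Also open, going by these compounds, is whether bromo has the same effect on the other 4-chlorophenyl ring, or in the methyl ester of compound 1.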